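The source may report more compounds than this note shows. Statements on the series, on what has been measured and on what is new or still open speak of the compounds shown alone.

For the measured compounds named here, the compounds measured so far in a functional assay on HCT-116 cells (Homo sapiens) for antiproliferative activity, with a stated time of 72 h (on this read-out lower numbers stand for stronger inhibition and higher numbers for weaker inhibition), are these.
Compound 1, `CC(=O)Oc1ccccc1/C=C/c1nc2ccccc2c(=O)[nH]1`, gives > 25000 nM, which is a limit of the assay rather than a number.
Compound 2, `CC(=O)Oc1cccc(/C=C/c2nc3ccccc3c(=O)[nH]2)c1`, gives 15300 nM.
Compound 3, `COc1ccccc1/C=C/c1nc2ccccc2c(=O)[nH]1`, gives 2470 nM.

Compound 1 and compound 2 have the same atoms joined differently; the difference between the two cores is not broken down here. Compound 3 differs from compound 1 by methyl in place of acetyl on an oxygen on an aromatic ring, and this change gives an at least 10-fold lower number from compound 1 to compound 3 (1.00 log units; beyond the scatter). That compound 1 sits at the limit is recorded as the limit of > 25000 nM in this assay, at which 1 of the 3 values shown sits. Of the two plain numbers, compound 2 stands highest, and compound 3 is the nearest to it.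

Compound 4, `COc1cccc(/C=C/c2nc3ccccc3c(=O)[nH]2)c1`, has not yet been measured in this assay. It differs from compound 2 by methyl in place of acetyl on an oxygen on an aromatic ring, the same change as that from compound 1 to compound 3, at a place described in the same words. Resting on compound 2 with 15300 nM and on an at least 10-fold lower number from compound 1 to compound 3 (1.00 log units; beyond the scatter), compound 4 is expected to give about 2000 nM, somewhere between 700 nM and 6000 nM, which would be an estimated step of a 7.7-fold lower number from compound 2 to compound 4 (0.88 log units; beyond the scatter).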

Compound 4, half-maximal inhibitory concentration: > 25000 nM
Compound 4: no number, only a limit (the forecaster's own chance of this, stated with the estimate: 5%); middle value at least 12-fold (1.09 log units) from the limit.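

The change from acetoxy to methoxy gives an at least 1.6-fold higher number from compound 2 to compound 4 (0.21 log units; that floor lies within the scatter), and the same change on the two cores does not agree in this assay: the same change on two cores in this assay, an at least 10-fold lower number (1.00 log units; beyond the scatter) from compound 1 to compound 3 and an at least 1.6-fold higher number (0.21 log units; that floor lies within the scatter) from compound 2 to compound 4, at least 16-fold (1.21 log units) apart, beyond the scatter of two such steps

Each of the two steps rests on a limit of the assay rather than on two plain numbers, so neither has an exact size: the limit of > 25000 nM in this assay, at which 2 of the 4 values shown sit.

This shows that the step seen on the core of compound 1 cannot be carried over as it stands to the core of compound 2, but it does not show why the two cores part, and two pairs of compounds give no rule for the series.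

The compounds shown leave open whether a hydrogen or an ethyl group in place of the acetyl on that oxygen would follow compound 3 or compound 4 in this assay. They also leave open how a longer chain on that oxygen, or an amine or a carboxylic acid in its place, would read on either core.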